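A few compounds are considered here, and "the series" means these few. Any claim that something is new, unique, unknown or untested is made for them only; others in the source may bear on it.

Compound 2 `Cc1cc(N2CCCC(O)C2)c(S(C)(=O)=O)cc1C(=O)N=C(N)N` holds the lowest number of the two measured in a functional assay for inhibition of sodium/hydrogen exchanger (Oryctolagus cuniculus) (a higher number here means a weaker inhibitor, a lower number a stronger inhibitor), giving 30 nM. For the measured compounds named here, its nearest neighbour is compound 1 `Cc1cc(-c2cc(Cl)cc(Cl)c2)c(S(C)(=O)=O)cc1C(=O)N=C(N)N`, which in this assay gives 130 nM; the single measured step, a 4.3-fold lower number from compound 1 to compound 2 (0.64 log units; beyond the scatter), is beyond the scatter and is the only one available.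

Compound 3 `Cc1cc(Oc2cncc(Cl)c2)c(S(C)(=O)=O)cc1C(=O)N=C(N)N` differs from compound 2 in one place: (5-chloropyridin-3-yl)oxy in place of 3-hydroxypiperidin-1-yl on an aromatic carbon.

The step from compound 1 to compound 2 bears on this change, though it runs the other way: there, 3-hydroxypiperidin-1-yl replaced 3,5-dichlorophenyl on the same aromatic carbon and the number fell by a 4.3-fold lower number from compound 1 to compound 2 (0.64 log units; beyond the scatter). Compound 3 again carries a chlorine-bearing six-membered aromatic ring at that carbon, now joined through an oxygen and with a ring nitrogen, and it loses the hydrogen-bond donor. A partial return toward the number of compound 1 is therefore expected, a step of a 2.7-fold higher number from compound 2 to compound 3 (0.43 log units; beyond the scatter) upward from compound 2, smaller than the measured step because a 4.3-fold lower number from compound 1 to compound 2 (0.64 log units; beyond the scatter) was measured with 3,5-dichlorophenyl as the group that left, whereas the group compound 3 carries is (5-chloropyridin-3-yl)oxy. Compound 3 is estimated at 80 nM, with a range from 30 nM to 220 nM.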

Compound 3, half-maximal inhibitory concentration: 14 nM
The estimate for compound 3 lay 5.7-fold (0.76 log units) above the measured number; measured number outside the range, below it.
By their numbers in this assay, from the lowest: compound 3; then compound 2; then compound 1.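

The change to (5-chloropyridin-3-yl)oxy gave a 2.1-fold lower number from compound 2 to compound 3 (0.33 log units; beyond the scatter) in this assay, so a hydrogen-bond donor in the group on this carbon, ortho to a methylsulfonyl group, is not required for a low number. An aromatic ring on this carbon does not by itself keep the number high either: the change from 3,5-dichlorophenyl gave a 9.3-fold lower number from compound 1 to compound 3 (0.97 log units; beyond the scatter), the largest step among the three compounds. Compound 1 and compound 3 both carry a chlorine-bearing aromatic ring and no hydrogen-bond donor in this group, yet they stand at opposite ends of the order, so neither feature alone sorts these compounds. No measurement beyond these numbers bears on why the order falls as it does.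

The compounds shown leave open whether the oxygen link, the ring nitrogen or the single chlorine accounts for the gap between compound 1 and compound 3, since all three differ together in that change. A 3,5-dichlorophenoxy group or a 5-chloropyridin-3-yl group joined directly to this carbon would separate these parts, and a plain piperidin-1-yl group would isolate the role of the hydroxyl in compound 2.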